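Benzyloxy for benzoyl on the shared core

The source may hold more compounds than are shown below. What is called first, only, known or untested is meant among the compounds shown, and "the series" means these compounds.

Three compounds share one core and differ only in the group carried on the aromatic ring. Compound 1 `CCS(=O)(=O)N(Cc1cccnc1)c1cccc(C(=O)c2ccccc2)c1` gives 1100 nM in an assay on isolated protein with metabotropic glutamate receptor 2 (Homo sapiens) as the target; on this read-out higher numbers stand for an effect only at larger amounts of compound and lower numbers for an effect already at smaller amounts; compound 2 `CCS(=O)(=O)N(Cc1cccnc1)c1ccc(C(C)c2ccccc2)cc1` gives 1400 nM and compound 3 `CCS(=O)(=O)N(Cc1cccnc1)c1ccc(COc2ccccc2)cc1` gives 2100 nM. Compound 1 holds the lowest of the three numbers, though its gaps to compound 2 and to compound 3 both lie within the scatter. Compound 4 `CCS(=O)(=O)N(Cc1cccnc1)c1cccc(OCc2ccccc2)c1` is not yet measured; it differs from compound 1 in that (benzyloxy in place of benzoyl on an aromatic carbon). Among the measured compounds shown here, the only measured step that bears on such a change, a 1.5-fold higher number from compound 2 to compound 3 (0.18 log units; within the scatter), exchanged a carbon-linked phenyl for an oxygen-linked one and stayed within the scatter. A step of similar size is therefore expected here, a 1.5-fold higher number from compound 1 to compound 4 (0.16 log units; within the scatter), and compound 4 is estimated at 1600 nM, between 600 nM and 4500 nM.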

Compound 4, half-maximal effective concentration: 440 nM
Compound 4: the middle estimate sits 3.6-fold (0.56 log units) above what was measured, and the stated range ends above it.
By their numbers in this assay, from the lowest: compound 4; then compounds 1, 2 and 3 (each within the scatter of the next).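

On this aromatic carbon, meta to a large group, benzyloxy in place of benzoyl gives a 2.5-fold lower number from compound 1 to compound 4 (0.40 log units; beyond the scatter) in this assay and is the first step among these compounds to lie beyond the scatter. The leaving and entering groups match in heavy atoms, aromatic ring and hydrogen-bond acceptor, so the number at this position moves even with those counts unchanged.

Going by these compounds, whether an amine, a carboxylic acid or a longer chain in place of benzyloxy on this aromatic carbon would keep the number of compound 4 stays open. Nothing measured here accounts for the step.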